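Butyl Exchanged for Cyclohexyl on the Amide Nitrogen

The source may report more compounds than this note shows. Statements on the series, on what has been measured and on what is new or still open speak of the compounds shown alone.

Compound 1 `COc1cc2c(cc1OC)C(CC(N)=O)CC2`: 31.3%
Compound 2 `CCCCNC(=O)CC1CCc2cc(OC)c(OC)cc21`: 25%

Both compounds were tested in a functional assay on the whole organism (strain Wistar) for inhibition, with Rattus norvegicus as the target, read by paw edema, with stated times of 60 min and 4 h, at a dose of 100 mg/kg by the oral route; a higher number here means more inhibition at the dose given (going by the name of the read-out), a lower number less inhibition. Compound 1 gives 31.3%, and compound 2 gives 25%. Among the compounds with values here, the single measured step between them, a number 6.3 percentage points lower from compound 1 to compound 2 (within the scatter), lies within the scatter, so compound 2 stands alongside compound 1 with no difference beyond the scatter between the two numbers.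

Compound 3 `COc1cc2c(cc1OC)C(CC(=O)NC1CCCCC1)CC2` carries cyclohexyl in place of butyl on an amide-type nitrogen. Within the data shown here, no measured step exchanges one carbon substituent on the amide nitrogen for another; the only measured step at this position, a number 6.3 percentage points lower from compound 1 to compound 2 (within the scatter), added a substituent where hydrogen had stood and remained within the scatter. On that basis no step beyond the scatter is expected from compound 2 to compound 3, and the expected step is a number 2 percentage points higher from compound 2 to compound 3 (within the scatter). Compound 3 is accordingly estimated to give 27% in this assay, with an expected range from 10% to 45%.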

Compound 3, a percentage reported as inhibition, in the whole organism at one dose (the size of the read-out at that dose, not a potency): 50%
Compound 3: middle estimate off by 23 percentage points, on the low side; the measured number lies above the stated range.
By their numbers in this assay, from the lowest: compounds 2 and 1 (each within the scatter of the next); then compound 3.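

In this assay the amide nitrogen now proves to be a position where the substituent can shift the number beyond the scatter: the exchange of butyl for cyclohexyl gives a number 25 percentage points higher from compound 2 to compound 3 (beyond the scatter) whereas the earlier exchange of the amide hydrogen for butyl gave only a number 6.3 percentage points lower from compound 1 to compound 2 (within the scatter) and stayed within it. Compound 3 also separates from the amide that carries no substituent, with a number 18.7 percentage points higher from compound 1 to compound 3 (beyond the scatter) so a carbon group at this nitrogen does not by itself set the outcome, as butyl stays within the scatter of the amide hydrogen while cyclohexyl does not. Nothing measured here explains why the cyclohexyl group behaves differently from butyl.

The change brings in a ring and more carbon together, so the compounds shown cannot separate the two, and a hexyl chain, a cyclopentyl ring or a phenyl ring on the same nitrogen would be needed to tell them apart. They also leave open whether an amine or a carboxylic acid on the cyclohexyl ring would keep the gain, and how the compounds rank at doses other than the single one reported.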